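Chloro for methyl in an imidazoline aryl amine series

The source may report more compounds than this note shows. Statements on the series, on what has been measured and on what is new or still open speak of the compounds shown alone.

Compound 1 `CSc1ccc(C)cc1NCC1=NCCN1` is measured in an assay on CHO cells for binding affinity to Alpha-2B adrenergic receptor (Homo sapiens), read by radioligand binding (on this read-out lower numbers stand for stronger inhibition and higher numbers for weaker inhibition), where compound 1 gives 977 nM. Of the two numbers shown, compound 1 stands highest, though its neighbour compound 3 `CSc1cc(F)ccc1NCC1=NCCN1`, with 851 nM in this assay, sits within the scatter of it, so the two cannot be ordered. Compound 2 `Cc1ccc(S(C)(=O)=O)c(NCC2=NCCN2)c1` gives only a limit in this assay, < 6310 nM; accordingly the step that the limit leaves unreadable from compound 1 to compound 2 cannot be read, as the limit of < 6310 nM in this assay, at which 1 of the 3 values shown sits, states. The unmeasured compound 4 `CSc1ccc(Cl)cc1NCC1=NCCN1` differs from compound 1 by chloro in place of methyl on an aromatic carbon. For the measured compounds named here, none of the measured steps concerns this change: the one measured step exchanges the methylsulfanyl group and is unreadable, and compound 3 differs from compound 1 in two places. Going by the values given here, with no step bearing on it, the expected change in this assay for compound 4 is none beyond the scatter, that is a 1.1-fold lower number from compound 1 to compound 4 (0.04 log units; within the scatter). Compound 4 is therefore estimated at 900 nM in this assay, with a range from 300 nM to 2700 nM.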

Compound 4, inhibition constant: 676 nM
Estimate against measurement, compound 4: 1.3-fold (0.12 log units) above, within the range that was stated.
By their numbers in this assay, from the lowest: compounds 4, 3 and 1 (each within the scatter of the next).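

For the compounds shown here, the exchange of methyl for chloro on this aromatic carbon, para to the methylsulfanyl group, gives the first readable step at this position: in this assay it is a 1.4-fold lower number from compound 1 to compound 4 (0.16 log units; within the scatter), so the two compounds cannot be told apart. The earlier compounds could not show this, as the only step then listed concerned the methylsulfanyl group and could not be read. Nothing shown gives a reason for this step.

The compounds shown leave open whether any group at this carbon moves the number beyond the scatter, since only methyl and chloro appear there, and a methoxy group, an amine or a carboxylic acid might behave differently. They also leave open whether the same exchange would give a similar step with methylsulfonyl in place of methylsulfanyl.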